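From 2,4-Dichlorophenyl to 2,4-Difluorophenyl in a Growth Inhibitor

The source may hold more compounds than are shown below. What is called first, only, known or untested is meant among the compounds shown, and "the series" means these compounds.

For the measured compounds named here, in a functional assay on MCF7 cells (Homo sapiens) (a lower number here means a stronger inhibitor of growth, a higher number a weaker inhibitor of growth), compound 3 `O=S(=O)(/C=C/c1ccc(Cl)cc1Cl)Cc1ccc(Nc2ncnc3ccccc23)cc1` gives 4000 nM, the lowest of the three numbers so far. Compound 2 `O=S(=O)(/C=C/c1ccc(Cl)cc1)Cc1ccc(Nc2ncnc3ccccc23)cc1` gives 52000 nM, and compound 1 `O=S(=O)(/C=C/c1ccc(Br)cc1)Cc1ccc(Nc2ncnc3ccccc23)cc1` gives 91000 nM.

Compound 4 `O=S(=O)(/C=C/c1ccc(F)cc1F)Cc1ccc(Nc2ncnc3ccccc23)cc1` keeps the rest of compound 3 and changes one group: 2,4-difluorophenyl in place of 2,4-dichlorophenyl on a double-bonded chain carbon bound to a double-bonded chain carbon. Three measured steps offer guidance. Exchanging one halogen for another, chloro in place of bromo, gave a 1.8-fold lower number from compound 1 to compound 2 (0.24 log units; within the scatter), so that swap showed no clear effect. Adding a chloro gave a far larger step, a 13-fold lower number from compound 2 to compound 3 (1.11 log units; beyond the scatter), and the full change of group gave a 23-fold lower number from compound 1 to compound 3 (1.36 log units; beyond the scatter). Going by the values given here, no fluorine-bearing compound has been measured, so these steps guide the estimate only loosely. The low number of compound 3 came with its 2,4-dichlorophenyl group, and it may not fully carry over to the 2,4-difluorophenyl group. In this assay, the expected change is a moderate rise, a 3.0-fold higher number from compound 3 to compound 4 (0.48 log units; beyond the scatter). For compound 4 the estimated value is 12000 nM, with an expected range of 3000 nM to 50000 nM.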

Compound 4, concentration for 50% growth inhibition: > 100000 nM
Compound 4 ended at the assay's limit; the forecaster's own chance of this, stated with the estimate: 10%; middle value at least 8.3-fold (0.92 log units) away from the limit.
By their numbers in this assay, from the lowest: compound 3; then compounds 2 and 1 (each within the scatter of the next). At a limit, above all of these: compound 4.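

Compound 4 stands at a limit of this assay, not at a measured number: the limit of > 100000 nM in this assay, at which 1 of the 4 values shown sits. Even so, the change from chloro to fluoro on this ring has a large effect, an at least 25-fold higher number from compound 3 to compound 4 (1.39 log units; beyond the scatter), whereas the only earlier halogen exchange, chloro in place of bromo, gave a 1.8-fold lower number from compound 1 to compound 2 (0.24 log units; within the scatter). So among the compounds shown, a 2,4-dihalophenyl group does not by itself bring a low number, and the other two steps to compound 4, an at least 1.9-fold higher number from compound 2 to compound 4 (0.28 log units; that floor lies within the scatter) and an at least 1.0-fold higher number from compound 1 to compound 4 (0.04 log units; that floor lies within the scatter), cannot be read, since their floors lie within the scatter.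

On these data alone, it remains open how a 2,4-dibromophenyl or a 2,4-dimethylphenyl group would behave here. A 2-chlorophenyl group would show whether the second chloro of compound 3 is needed.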